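Swapping a heptyl chain for a trifluoromethoxyphenyl ring

The compounds below may be only part of what the source reports. "The series", "measured", "known", "first", "only" and "open" are said of these compounds alone.

Measured compounds:
compound 1, `COc1nc2ccc(Br)cc2cc1C(c1ccccc1)n1cc(-c2ccc(Br)cc2)nn1`: 6.92%
compound 2, `CCCCCCCc1cn(C(c2ccccc2)c2cc3cc(Br)ccc3nc2OC)nn1`: 9.7%
compound 3, `CCCCCc1cn(C(c2ccccc2)c2cc3cc(Br)ccc3nc2OC)nn1`: -9.81%

In an ADME assay on HeLa cells (Homo sapiens) for cytotoxicity, read by sulforhodamine B assay, with a stated time of 48 h, tested at 10 uM (on this read-out higher numbers stand for more inhibition at the one concentration tested (going by the name of the read-out) and lower numbers for less inhibition), compound 2 gives the highest of the three numbers, yet the nearest gap is within the scatter, a number 2.8 percentage points higher from compound 1 to compound 2 (within the scatter), while the other gap lies further off, a number 19.5 percentage points lower from compound 2 to compound 3 (beyond the scatter). Compound 4, `COc1nc2ccc(Br)cc2cc1C(c1ccccc1)n1cc(-c2ccc(OC(F)(F)F)cc2)nn1`, has not yet been tested. It differs from compound 2 by 4-(trifluoromethoxy)phenyl in place of heptyl on an aromatic carbon. Among the measured compounds shown here, the step that bears on this is the one from compound 1 to compound 2, which exchanged a 4-bromophenyl for the heptyl and stayed within the scatter. Putting a ring back in that position is therefore expected to move this assay by a number 2.7 percentage points lower from compound 2 to compound 4 (within the scatter), no further than the scatter. Compound 4 is thus estimated at 7%, between -5% and 19%.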

Compound 4, a percentage reported as inhibition, at one concentration (the size of the read-out at that concentration, not a potency): -2.24%
Compound 4: middle estimate off by 9.2 percentage points, on the high side, within the range that was stated.
By their numbers in this assay, from the lowest: compounds 3, 4, 1 and 2 (each within the scatter of the next, the first and the last beyond it).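

In this assay the effect of putting this ring on the aromatic carbon depends on which chain it replaces: 4-(trifluoromethoxy)phenyl in place of heptyl gives a number 11.9 percentage points lower from compound 2 to compound 4 (beyond the scatter) and so separates the two groups. The same ring in place of pentyl gives a number 7.6 percentage points higher from compound 3 to compound 4 (within the scatter) and does not separate them. Trifluoromethoxy in place of bromo gives a number 9.2 percentage points lower from compound 1 to compound 4 (within the scatter) and so leaves that swap unresolved.

From the compounds shown here alone, whether an amine or a carboxylic acid on this aromatic carbon would shift the number remains open. Nothing available explains these differences.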